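Working notes: fluorophenyl to thiazolyl exchange at the aromatic carbon

The compounds below may be only part of what the source reports. "The series", "measured", "known", "first", "only" and "open" are said of these compounds alone.

Measured so far:
- compound 1, `COc1ncc(-c2ccccc2)cc1[C@@H](c1ccccc1)[C@@](O)(CCN(C)C)c1cc(F)cc(F)c1`: in a toxicity assay on HeLa cells (Homo sapiens) for cytotoxicity (on this read-out lower numbers stand for higher toxicity in this test and higher numbers for lower toxicity in this test), compound 1 gives 28.8 ug/mL
- compound 3, `COc1ncc(-c2ccccc2)cc1[C@@H](c1ccccc1)[C@@](O)(CCN(C)C)c1cccc2ccccc12`: in this assay compound 3 gives 30.4 ug/mL
- compound 2, `COc1nc(-c2ccc(F)cc2)ccc1[C@@H](c1ccccc1)[C@@](O)(CCN(C)C)c1cccc2ccccc12`: in this assay compound 2 reports only a limit, > 64 ug/mL, and no number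

Compound 2 therefore sits at the limit of > 64 ug/mL in this assay, at which 1 of the 3 values shown sits. Compound 4, `COc1nc(-c2cnsc2)ccc1[C@@H](c1ccccc1)[C@@](O)(CCN(C)C)c1cccc2ccccc12`, differs from compound 2 by 1,2-thiazol-4-yl in place of 4-fluorophenyl on an aromatic carbon. For the measured compounds named here, the single measured step, a 1.1-fold higher number from compound 1 to compound 3 (0.02 log units; within the scatter), concerns a different place in the molecule and does not bear on this exchange. Going by the values given here, no measured step speaks to the change at the aromatic carbon, so the expectation for compound 4 is a step of no size beyond the scatter, a number no higher from compound 2 to compound 4 (the limit leaves the size open). Compound 4 is estimated at 64 ug/mL, with a range from 30 ug/mL to 130 ug/mL.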

Compound 4, half-maximal cytotoxic concentration: 28.8 ug/mL
Beside the measured number, compound 4's estimate is 2.2-fold (0.35 log units) above it; the measured number lies below the stated range.
By their numbers in this assay, from the lowest: compounds 1, 4 and 3 (each within the scatter of the next). At a limit, above all of these: compound 2.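

In this assay, 1,2-thiazol-4-yl in place of 4-fluorophenyl on the aromatic carbon next to the ring nitrogen gives an at least 2.2-fold lower number from compound 2 to compound 4 (0.34 log units; beyond the scatter). For the compounds shown here, this is the first step at this position, and the first beyond the scatter, so the read-out responds to this exchange. Compound 2 gives only a limit, > 64 ug/mL, and not a number, so the step has a lower bound and no fixed size.

From the compounds shown here alone, whether the sulfur and nitrogen of the entering ring or the loss of the fluorine carries the step stays open. So does the read-out with an amine or a carboxylic acid on this aromatic carbon.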